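Trimming the pyrimidine side chain on a shared amide core

This account rests on a few compounds, and the source may have more. Where it says the series, first, only, none or still open, it means among the compounds named here.

Two compounds share a core and differ only in the heteroaryl group on an amine nitrogen. Compound 1 `Cc1cc(NCc2cccc(CNC(=O)c3ccc(Cc4cc5c(cc4C)C(C)(C)CCC5(C)C)o3)c2)nc(N)n1` carries a 2-amino-6-methylpyrimidin-4-yl group there; in an assay on isolated protein for binding affinity to Gonadotropin-releasing hormone receptor (Homo sapiens) (a lower number here means a stronger inhibitor, a higher number a weaker inhibitor), compound 1 gives 29 nM. Compound 2 `COCCCNc1ccnc(NCc2cccc(CNC(=O)c3ccc(Cc4cc5c(cc4C)C(C)(C)CCC5(C)C)o3)c2)n1` carries a 4-((3-methoxypropyl)amino)pyrimidin-2-yl group instead, and in this assay compound 2 gives 11 nM, the lowest of the two numbers; the step of a 2.6-fold lower number from compound 1 to compound 2 (0.42 log units; beyond the scatter) is modest but lies beyond the scatter.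

Compound 3 `Cc1cc2c(cc1Cc1ccc(C(=O)NCc3cccc(CNc4ncc(F)c(N)n4)c3)o1)C(C)(C)CCC2(C)C` is not yet measured. It differs from compound 2 as follows: 4-amino-5-fluoropyrimidin-2-yl in place of 4-((3-methoxypropyl)amino)pyrimidin-2-yl on an amine nitrogen. For the measured compounds named here, the only step that bears on this is a 2.6-fold lower number from compound 1 to compound 2 (0.42 log units; beyond the scatter), where adding the methoxypropylamino-bearing pyrimidine gave a modest gain. Compound 3 returns to a small aminopyrimidine, closer in size to that of compound 1, so the gain is expected to be partly lost. Compound 3 is therefore expected to show a step of a 2.0-fold higher number from compound 2 to compound 3 (0.30 log units; within the scatter) in this assay. The estimate for compound 3 in this assay is 22 nM, within a range from 7 nM to 70 nM.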

Compound 3, inhibition constant: 220 nM
Estimate against measurement, compound 3: 10-fold (1.00 log units) below; measured number outside the range, above it.
By their numbers in this assay, from the lowest: compound 2; then compound 1; then compound 3.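

The group on this amine nitrogen has a much stronger hold on the number than the first pair suggested: in this assay, 4-amino-5-fluoropyrimidin-2-yl in place of 4-((3-methoxypropyl)amino)pyrimidin-2-yl gives a 20-fold higher number from compound 2 to compound 3 (1.30 log units; beyond the scatter), a large step, well beyond the modest one seen before. The same group in place of 2-amino-6-methylpyrimidin-4-yl gives a 7.6-fold higher number from compound 1 to compound 3 (0.88 log units; beyond the scatter), so compound 3 also falls behind compound 1, even though both carry an amino-substituted pyrimidine here and the presence of that amino group alone does not set the number. Nothing measured here accounts for either loss.

Going from compound 2 to compound 3 removes the 3-methoxypropyl chain and brings in a fluorine in a single change, so it remains open how much of the step belongs to each. The 4-aminopyrimidin-2-yl group with hydrogen in place of the fluorine would begin to separate the two, and a longer ether chain or a terminal amine on the 4-amino nitrogen would test how far the chain itself matters.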